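Chloro in place of methoxy on compound 1

The source may hold more compounds than are shown below. What is called first, only, known or untested is meant among the compounds shown, and "the series" means these compounds.

Going by the values given here, compound 1 `COc1ccc(-c2nc3ccccn3c2Sc2ccccc2)cc1` has the higher number of the two compounds measured so far in a functional assay on HepG2 cells (Homo sapiens) for inhibition, read by MTT assay, with a stated time of 48 h; on this read-out lower numbers stand for stronger inhibition and higher numbers for weaker inhibition. There, compound 1 gives 54200 nM and compound 2 `CS(=O)(=O)c1ccc(-c2nc3ccccn3c2Sc2cccc3ccccc23)cc1` gives 13600 nM, a gap beyond the usual scatter. These two compounds differ in more than one place, so the gap cannot be read as the result of any single change.

The next compound is compound 3 `Clc1ccc(-c2nc3ccccn3c2Sc2ccccc2)cc1`, which carries chloro in place of methoxy on an aromatic carbon, para to a large group: chloro in place of methoxy on an aromatic carbon. Among the compounds with values here, no measured pair shows this change, so the expectation is loose. The estimated step of a 1.4-fold lower number from compound 1 to compound 3 (0.15 log units; within the scatter) in this assay is small, towards a lower number, and not expected to go beyond the scatter. For compound 3 the estimated value is 38000 nM, with an expected range of 15000 nM to 90000 nM.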

Compound 3, half-maximal inhibitory concentration: 13900 nM
Estimate against measurement, compound 3: 2.7-fold (0.44 log units) above; measured number below the stated range.
By their numbers in this assay, from the lowest: compounds 2 and 3 (each within the scatter of the next); then compound 1.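

Going from 4-methoxyphenyl to 4-chlorophenyl gives a 3.9-fold lower number from compound 1 to compound 3 (0.59 log units; beyond the scatter) in this assay and is the first single-place step in the series. It shows that the group on this aromatic carbon affects the read-out, which the gap between the two earlier compounds could not show because they differ in more than one place. The change swaps methoxy, with one hydrogen-bond acceptor, for chloro, with none, but no measurement here bears on what lies behind the step.

Going by these compounds, one swap cannot separate the loss of methoxy from the gain of chloro, and how an amine, a carboxylic acid or a longer alkoxy chain would read at this position remains open. On these data alone, whether the same change gives a similar step elsewhere also remains open.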